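A few compounds are considered here, and "the series" means these few. Any claim that something is new, unique, unknown or untested is made for them only; others in the source may bear on it.

Measured so far in a functional assay on THP-1 cells (Homo sapiens) for cytotoxicity, read by sulforhodamine B assay, with a stated time of 48 h; a higher number here means a weaker inhibitor, a lower number a stronger inhibitor:

- compound 1 `COc1cc(/C=C/C(=O)/C=C/c2cccc3ccccc23)ccc1OCc1cn(CCCOc2cc(=O)oc3ccccc23)nn1` gives 8410 nM
- compound 2 `COc1cc(/C=C/C(=O)/C=C/c2cccs2)ccc1OCc1cn(CCOc2cc(=O)oc3ccccc23)nn1` gives 7140 nM
- compound 3 `COc1cccc(/C=C/C(=O)/C=C/c2ccc(OCc3cn(CCOc4cc(=O)oc5ccccc45)nn3)c(OC)c2)c1` gives 7130 nM

Compound 2 at 7140 nM lies within the usual scatter of both compound 3 and compound 1, so these three numbers cannot be ranked. Compound 4 `COc1cc(/C=C/C(=O)/C=C/c2cc(OC)c(OC)c(OC)c2)ccc1OCc1cn(CCOc2cc(=O)oc3ccccc23)nn1` has not yet been measured. It differs from compound 2 in one place, with 3,4,5-trimethoxyphenyl in place of thiophen-2-yl on a double-bonded chain carbon bound to a double-bonded chain carbon.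

Among the compounds with values here, the one measured step that bears on this, a 1.0-fold lower number from compound 2 to compound 3 (0.00 log units; within the scatter), replaces the same thiophen-2-yl with 3-methoxyphenyl and stays within the scatter. Compound 1 differs from compound 2 in more than one place, so it offers no clean comparison. Within the data shown here, no measured compound carries 3,4,5-trimethoxyphenyl, so this single step is thin evidence. On that basis, no change beyond the scatter is expected in this assay, in either direction. The expected change, a 1.0-fold lower number from compound 2 to compound 4 (0.01 log units; within the scatter), is only an estimate. For compound 4 the estimated value is 7000 nM with an expected range from 3200 nM to 15000 nM in this measurement.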

Compound 4, half-maximal inhibitory concentration: 820 nM
Compound 4: the middle estimate sits 8.5-fold (0.93 log units) above what was measured; measured number below the stated range.
By their numbers in this assay, from the lowest: compound 4; then compounds 3, 2 and 1 (each within the scatter of the next).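

In this assay, this position on the chain proved able to shift the number beyond the scatter, which the earlier compounds had not shown: the change gives an 8.7-fold lower number from compound 2 to compound 4 (0.94 log units; beyond the scatter), and the same group gives an 8.7-fold lower number from compound 3 to compound 4 (0.94 log units; beyond the scatter). Swapping thiophen-2-yl for 3-methoxyphenyl had given only a 1.0-fold lower number from compound 2 to compound 3 (0.00 log units; within the scatter), so among these compounds a six-membered aromatic ring of carbon with one methoxy group is not enough, and the gain appears only with 3,4,5-trimethoxyphenyl. Nothing measured here accounts for that gain.

The compounds shown leave open whether all three methoxy groups are needed, or whether a phenyl ring with two methoxy groups would give the same number. They also leave open how this position would respond to a ring carrying a dimethylamino group or a carboxylic acid.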